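Aryl swap on the triazole: stability notes for compound 4

The compounds below may be only part of what the source reports. "The series", "measured", "known", "first", "only" and "open" are said of these compounds alone.

Measured so far in an ADME assay (liver) for metabolic stability, with Liver microsome (Rattus norvegicus) as the target, using microsomes, with a stated time of 0.5 h, tested at 1 uM; a higher number here means that more of the compound is left, a lower number that less of the compound is left:
- compound 1 `C[C@H](c1ccccc1)N1C(=O)O[C@](Cc2ccccc2)(c2ncc(Cc3ccccc3)o2)C1=O` gives 0%
- compound 2 `C[C@H](c1ccccc1)N1C(=O)O[C@](Cc2ccccc2)(c2nnc(-c3ccccc3)[nH]2)C1=O` gives 29%
- compound 3 `C[C@H](c1ccccc1)N1C(=O)O[C@](Cc2ccccc2)(c2nnc(-c3ccc(Cl)c(Cl)c3)[nH]2)C1=O` gives 41%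

Compound 3 stands highest of the three numbers in this assay. Its nearest neighbour is compound 2, and that step, a number 12 percentage points higher from compound 2 to compound 3 (beyond the scatter), lies beyond the scatter. Compound 1 is furthest away: its value and that of compound 3 differ by a wide margin, again beyond the scatter.

Compound 4 `COc1cc(OC)cc(-c2nnc([C@@]3(Cc4ccccc4)OC(=O)N([C@H](C)c4ccccc4)C3=O)[nH]2)c1` differs from compound 3 in one place: 3,5-dimethoxyphenyl in place of 3,4-dichlorophenyl on an aromatic carbon. Among the compounds with values here, only one measured step touches this position, a number 12 percentage points higher from compound 2 to compound 3 (beyond the scatter), a modest gain obtained by putting 3,4-dichlorophenyl in place of phenyl. Within the data shown here, no measured compound carries a 3,5-dimethoxyphenyl at this place, so the direction of the coming step in this assay rests on thin ground. With the 3,4-dichlorophenyl that went with the gain in a number 12 percentage points higher from compound 2 to compound 3 (beyond the scatter) removed, the expectation for compound 4 is a modest fall, a number 14 percentage points lower from compound 3 to compound 4 (beyond the scatter), though a result within the scatter cannot be excluded. Compound 4 is therefore estimated at 27%, with a range from 8% to 48%.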

Compound 4, percent of the compound remaining: 37%
Compound 4: the middle estimate sits 10 percentage points below what was measured; the measured number falls inside the stated range.
By their numbers in this assay, from the lowest: compound 1; then compounds 2, 4 and 3 (each within the scatter of the next, the first and the last beyond it).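

In this assay, the swap at this position gives a number 4 percentage points lower from compound 3 to compound 4 (within the scatter), so on the aromatic carbon of the five-membered aromatic ring with 3 nitrogen, the 3,4-dichlorophenyl can give way to a 3,5-dimethoxyphenyl, with no chlorine and 2 hydrogen-bond acceptors, without a step beyond the scatter. Measured against phenyl, the same group gives a number 8 percentage points higher from compound 2 to compound 4 (within the scatter), which places compound 4 within the scatter of both compound 2 and compound 3, although those two lie beyond the scatter of each other, and so this change cannot be ordered against either neighbour. No supporting data accompany these numbers to account for them.

Among the compounds shown, the substituent effects on this phenyl ring remain unresolved: a single chlorine or a single methoxy would show whether either group alone matters, and the 3,5-dimethoxyphenyl and 3,4-dichlorophenyl differ in both substituent and ring position. Going by these compounds, it also remains open whether a more different group on this ring, such as an amine or a carboxylic acid, would move the number in this assay beyond the scatter of compound 3.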